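A few compounds are considered here, and "the series" means these few. Any claim that something is new, unique, unknown or untested is made for them only; others in the source may bear on it.

Measured so far:
- compound 1 `CC(C)OC(=O)Nc1nc2ccc(NC(=O)c3c(Cl)cccc3Cl)cc2s1` — in a functional assay on WI-38 VA13 cells (Homo sapiens) for cytotoxicity (a higher number here means that more compound is needed for the effect, a lower number that less compound is needed), compound 1 gives 0.0026 ug/mL
- compound 2 `CCCCCNc1nc2ccc(NC(=O)c3c(Cl)cccc3Cl)cc2s1` — in this assay compound 2 gives 0.27 ug/mL

Among the measured compounds shown here, compound 2 stands at the higher of the two numbers in this assay, so more of it is needed than of compound 1; the only measured step, a 100-fold higher number from compound 1 to compound 2 (2.02 log units; beyond the scatter), shows that what sits on this nitrogen on the aromatic ring changes the number strongly. Compound 3 `COc1cccc(Nc2nc3ccc(NC(=O)c4c(Cl)cccc4Cl)cc3s2)c1` is the next step from compound 2: 3-methoxyphenyl in place of pentyl on a nitrogen on an aromatic ring. For the measured compounds named here, no measured pair covers an exchange of a chain for an aromatic ring at this position, so the one step of a 100-fold higher number from compound 1 to compound 2 (2.02 log units; beyond the scatter) only says that changes here can be large, not in which direction this one will go. Compound 3 is therefore expected to stay near compound 2, with a wide range either way, an estimated step of a 1.1-fold higher number from compound 2 to compound 3 (0.05 log units; within the scatter). The estimate for compound 3 in this assay is 0.3 ug/mL, between 0.04 ug/mL and 2.5 ug/mL.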

Compound 3, half-maximal effective concentration: > 7.2 ug/mL
Compound 3 gave a limit, no number; the forecaster's own chance of this, stated with the estimate: 5%; middle value at least 24-fold (1.38 log units) away from the limit.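

Compound 3 has no exact number in this read-out, only a limit: the limit of > 7.2 ug/mL in this assay, at which 1 of the 3 values shown sits.

Placing 3-methoxyphenyl in place of pentyl on this nitrogen gives an at least 26-fold higher number from compound 2 to compound 3 (1.42 log units; beyond the scatter), so exchanging a chain for an aromatic ring here moves the number strongly upward, a direction the earlier step alone could not foretell. Against the isopropoxycarbonyl group, the same aromatic group gives an at least 2700-fold higher number from compound 1 to compound 3 (3.44 log units; beyond the scatter), which shows that the three groups on this nitrogen span a very wide range in this assay.

From the compounds shown here alone, how far compound 3 truly lies past its limit remains open, and so does whether the ring itself or its methoxy group accounts for the change. An unsubstituted phenyl on this nitrogen would separate those two parts, and a methoxycarbonyl group would test how much the size of the isopropyl part matters.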